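Furan Amide Replacing Cyanophenyl Amide in a Thiazole Series

A few compounds are considered here, and "the series" means these few. Any claim that something is new, unique, unknown or untested is made for them only; others in the source may bear on it.

Measured so far:
compound 1, `CCOC(=O)c1sc(-c2cccc(NC(=O)c3cccc(F)c3)c2)nc1Nc1ccc(N2CCN(C)CC2)cc1`, 85.2% in a functional assay on Ramos cells (Homo sapiens) for antiproliferative activity, read by CCK-8 assay, with a stated time of 72 h, tested at 40 uM; on this read-out lower numbers stand for less inhibition and higher numbers for more inhibition at the one concentration tested (going by the name of the read-out);
compound 2, `CCOC(=O)c1sc(-c2cccc(NC(=O)c3ccc(C#N)cc3)c2)nc1Nc1ccc(N2CCN(C)CC2)cc1`, 97.5% in this assay.

Compound 2 stands highest of the two numbers shown in this assay; its nearest neighbour is compound 1, and the one measured step, a number 12.3 percentage points higher from compound 1 to compound 2 (beyond the scatter), lies beyond the scatter and is modest in size.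

Compound 3 is `CCOC(=O)c1sc(-c2cccc(NC(=O)c3ccco3)c2)nc1Nc1ccc(N2CCN(C)CC2)cc1`. It differs from compound 2 in one place: furan-2-yl in place of 4-cyanophenyl on a carbonyl carbon. For the measured compounds named here, no measured step involves a furan-2-yl group, so the only step that bears on the change is the swap on the same carbonyl carbon between compound 1 and compound 2, which was modest. Because compound 2 already gives 97.5%, little room remains upward, and a step downward of modest size or none beyond the scatter is expected as a number 9.5 percentage points lower from compound 2 to compound 3 (within the scatter). Compound 3 is estimated at 88%, with a range from 68% to 99%.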

Compound 3, a percentage reported as inhibition, at one concentration (the size of the read-out at that concentration, not a potency): 50.2%
Estimate against measurement, compound 3: 37.8 percentage points above; the measured number lies below the stated range.
By their numbers in this assay, from the lowest: compound 3; then compound 1; then compound 2.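

At this carbonyl carbon the choice of group matters far more than the earlier pair suggested: in this assay, furan-2-yl in place of 4-cyanophenyl gives a number 47.3 percentage points lower from compound 2 to compound 3 (beyond the scatter), and furan-2-yl in place of 3-fluorophenyl gives a number 35 percentage points lower from compound 1 to compound 3 (beyond the scatter). Both steps are large, whereas the exchange of one substituted phenyl group for the other gave only a number 12.3 percentage points higher from compound 1 to compound 2 (beyond the scatter), so among these three compounds the five-membered ring stands apart from the two six-membered ones. Nothing measured here accounts for the drop.

The compounds shown leave open whether the loss follows the furan ring itself or the absence of a substituent on the ring, and an unsubstituted phenyl or a thiophen-2-yl group at this carbonyl carbon could separate the two. These readings, each taken at one concentration, also leave the potency of all three compounds open.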